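Amino for fluoro in a series stuck at its limit

The compounds below may be only part of what the source reports. "The series", "measured", "known", "first", "only" and "open" are said of these compounds alone.

Values in a functional assay on HL-60 cells (Homo sapiens) for antiproliferative activity, read by MTT assay, with a stated time of 72 h (a higher number here means a weaker inhibitor, a lower number a stronger inhibitor), are these
Compound 1 `COc1cc(-c2ncnn2-c2cccc(N)c2)cc(OC)c1OC` gives > 10000 nM as a limit
Compound 2 `COc1cccc(-c2ncnn2-c2cc(OC)c(OC)c(OC)c2)c1` gives > 10000 nM as a limit
Compound 3 `COc1cc(-c2ncnn2-c2ccc(F)cc2)cc(OC)c1OC` gives > 10000 nM as a limit

Compound 3 yields only a limit and no number (the limit of > 10000 nM in this assay, at which 3 of the 3 values shown sit). Compound 4 `COc1cc(-c2ncnn2-c2ccc(N)cc2)cc(OC)c1OC` differs from it at one place (amino in place of fluoro on an aromatic carbon), with amino in place of fluoro on an aromatic carbon, para to a large group. Among the compounds with values here, the one measured step that bears on this is a step that the two limits leave unreadable from compound 1 to compound 3 and it gives no size to build on. Compound 1 already carries 3-aminophenyl and still gives only a limit (> 10000 nM). No clear step beyond the scatter is therefore expected in this assay and a further limit is the likeliest result. The expected change is a number no higher from compound 3 to compound 4 (the limit leaves the size open) and no more. For compound 4 the estimate is 10000 nM (expected range 2000 nM to 20000 nM).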

Compound 4, half-maximal inhibitory concentration: > 10000 nM
Compound 4 was reported as a limit (the forecaster's own chance of this, stated with the estimate: 65%); the middle value lies on the limit itself.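

No step can be read among compound 1, compound 3 and compound 4, each of which gives only a limit: the limit of > 10000 nM in this assay, at which 4 of the 4 values shown sit. The compounds shown leave open how far any of these changes shifts activity, and which change on the shared core would give a readable number.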